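This account rests on a few compounds, and the source may have more. Where it says the series, first, only, none or still open, it means among the compounds named here.

Compound 1 `COc1ccc(NC(=O)Nc2cc(C)nc3ccccc23)cc1`: in an ADME assay on HepG2 cells (Homo sapiens) for cytotoxicity, with a stated time of 72 h (on this read-out lower numbers stand for an effect already at smaller amounts and higher numbers for an effect only at larger amounts of compound), compound 1 gives > 25000 nM, which is a limit of the assay, not a number.
Compound 2 `Cc1cc(NC(=O)Nc2ccc(N)cc2)c2ccccc2n1`: compound 2 gives > 25000 nM, again a limit.
Compound 3 `Cc1cc(NC(=O)Nc2ccc(N(C)C)cc2)c2ccccc2n1`: compound 3 gives > 25000 nM, also a limit.

Compound 3 therefore stands only at a limit, as do both other values shown. Compound 4 `Cc1cc(NC(=O)Nc2ccc(C(N)=O)cc2)c2ccccc2n1` differs from compound 3 by carbamoyl in place of dimethylamino on an aromatic carbon. Among the measured compounds shown here, the steps that bear on this are those ending at compound 3, a step that the two limits leave unreadable from compound 1 to compound 3 and a step that the two limits leave unreadable from compound 2 to compound 3; both stay unreadable because of the limit of > 25000 nM in this assay, at which 3 of the 3 values shown sit. The same holds for a step that the two limits leave unreadable from compound 1 to compound 2. No size or direction of step can thus be read from the series, and the expectation is that compound 4 again shows no change beyond the scatter in this assay, so a step that the limit leaves unreadable from compound 3 to compound 4 is expected. Compound 4 is estimated at 30000 nM, between 12000 nM and 80000 nM, and most likely reported only as a limit.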

Compound 4, half-maximal effective concentration: > 25000 nM
Compound 4: a limit, no number; the forecaster's own chance of this, stated with the estimate: 80%; the middle value lies beyond the limit too.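

No new step can be read for compound 4 against compound 1, compound 2 or compound 3, because all of them stand at one limit: the limit of > 25000 nM in this assay, at which 4 of the 4 values shown sit.

The compounds shown leave open how these groups compare in this assay, as none gives a number.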